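The source may report more compounds than this note shows. Statements on the series, on what has been measured and on what is new or still open speak of the compounds shown alone.

Compound 3 `CN(C)C(=O)c1cc2cnc(Nc3ccc(C(=O)NCCCCN=C=S)cc3)nc2n1C1CCCC1` is one of three closely related compounds measured in a functional assay on NCI-H1299 cells (Homo sapiens) for inhibition, read by CCK-8 assay, with a stated time of 72 h, tested at 1 uM; on this read-out lower numbers stand for a weaker effect and higher numbers for a stronger effect at the one concentration tested. Compound 3 gives 55.2%, the second highest of the three numbers. Its nearest neighbour is compound 2 `CN(C)C(=O)c1cc2cnc(Nc3ccc(C(=O)NCCCN=C=S)cc3)nc2n1C1CCCC1`, which gives 65.1%; the gap a number 9.9 percentage points lower from compound 2 to compound 3 (within the scatter) lies within the scatter, so the two cannot be ranked. Compound 1 `CN(C)C(=O)c1cc2cnc(Nc3ccc(S(=O)(=O)NCCCN=C=S)cc3)nc2n1C1CCCC1`, which gives 41.3%, sits further away, with a number 13.9 percentage points higher from compound 1 to compound 3 (beyond the scatter) and a number 23.8 percentage points higher from compound 1 to compound 2 (beyond the scatter) both beyond the scatter.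

Compound 4 `CN(C)C(=O)c1cc2cnc(Nc3ccc(C(=O)NCCCCCCN=C=S)cc3)nc2n1C1CCCC1` has not yet been measured. It differs from compound 3 in one place: a group of 5 heavy atoms (3 carbon, 1 nitrogen, 1 sulfur; no ring) in place of a group of 3 heavy atoms (1 carbon, 1 nitrogen, 1 sulfur; no ring), on a saturated chain carbon, four bonds along the chain from an amide-type nitrogen. Within the data shown here, the only measured step that bears on this is the chain lengthening between compound 2 and compound 3, a number 9.9 percentage points lower from compound 2 to compound 3 (within the scatter), which stayed within the scatter. Taking that as the nearest guide, a further lengthening is expected to change little, perhaps nudging the number slightly downward, as a number 7.2 percentage points lower from compound 3 to compound 4 (within the scatter). Compound 4 is therefore estimated to give 48%, with a likely range from 30% to 65%.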

Compound 4, a percentage reported as inhibition, at one concentration (the size of the read-out at that concentration, not a potency): 49.4%
Estimate against measurement, compound 4: 1.4 percentage points below; the range from low to high includes it.
By their numbers in this assay, from the lowest: compounds 1, 4, 3 and 2 (each within the scatter of the next, the first and the last beyond it).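

Lengthening the chain again gives a number 5.8 percentage points lower from compound 3 to compound 4 (within the scatter) in this assay, so this single step cannot be told apart from the scatter. Taken across the series, however, the step of a number 15.7 percentage points lower from compound 2 to compound 4 (beyond the scatter) shows that the chain length at this position does matter once the two ends of the measured range are compared, even though neither single lengthening step can be read alone. The earlier gap to compound 1 also closes, with a number 8.1 percentage points higher from compound 1 to compound 4 (within the scatter), and no measurement here offers an explanation for either result.

The compounds shown leave open whether a longer chain than that of compound 4 would continue the same trend. They also leave open what an amine in place of the isothiocyanate at the chain end would do.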